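The compounds below may be only part of what the source reports. "The series", "measured", "known", "first", "only" and "open" are said of these compounds alone.

In a functional assay on the whole organism (strain albino) for inhibition, with Rattus norvegicus as the target, read by paw edema, with a stated time of 3 h, at a dose of 0.28 mmol/kg by the oral route (on this read-out lower numbers stand for less inhibition and higher numbers for more inhibition at the one dose given (going by the name of the read-out)), compound 1 `CCn1c(SCC(=O)c2ccccc2)nnc1-c1cc(OC)c(OC)c(OC)c1` gives 49%, which is the lowest of the three numbers recorded so far. Compound 2 `CCn1c(SC/C(=N/O)c2ccccc2)nnc1-c1cc(OC)c(OC)c(OC)c1` gives 69% in this assay, and compound 3 `CCn1c(SCC(=O)c2ccccc2)nnc1-c1ccc(OC)c(OC)c1` gives 61%. Two single-point changes were measured from compound 1: the first, a number 20 percentage points higher from compound 1 to compound 2 (beyond the scatter), replaces the ketone-bearing group on the saturated chain carbon bound to sulfur with its oxime counterpart; the second, a number 12 percentage points higher from compound 1 to compound 3 (beyond the scatter), removes one methoxy from the aromatic ring. Both steps move the number upward and beyond the scatter, but both touch parts of the molecule far from the one now in question.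

Compound 4 `C=CCn1c(SCC(=O)c2ccccc2)nnc1-c1cc(OC)c(OC)c(OC)c1` differs from compound 1 only on the other side of the core, at the chain carbon bound to the aromatic nitrogen: vinyl in place of methyl on a saturated chain carbon bound to an aromatic nitrogen. Cut one bond further out, the change reads ethyl to allyl. Neither measured step alters this chain, so nothing among the three compounds speaks to it directly, and the expectation rests on the small size of the change alone: a step of about a number 1 percentage points higher from compound 1 to compound 4 (within the scatter) is estimated, not beyond the scatter. Compound 4 is therefore expected to give about 50% in this assay, within a range of 36% to 64%.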

Compound 4, a percentage reported as inhibition, in the whole organism at one dose (the size of the read-out at that dose, not a potency): 66%
The estimate for compound 4 lay 16 percentage points below the measured number, and the stated range ends below it.
By their numbers in this assay, from the lowest: compound 1; then compounds 3, 4 and 2 (each within the scatter of the next).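

The chain on the aromatic nitrogen turns out not to be a silent part of the molecule in this assay: with ethyl giving way to allyl, the read-out shows a number 17 percentage points higher from compound 1 to compound 4 (beyond the scatter). Among these compounds, this is the first change at this place, and it shows that a single extra carbon carrying a double bond, with no ring, no hydrogen-bond donor or acceptor and no charge added, is enough to move the number beyond the scatter, so that all three places changed from compound 1 now raise it. Nothing available explains why this small change has such an effect.

On these data alone, what a propyl chain would give at this place stays open, and with it whether the step follows the added carbon or the double bond; a longer chain, a benzyl group or a propargyl group could test how far the trend runs. Also open, as far as these compounds go, is whether allyl on the nitrogen would add to the oxime of compound 2 or to the missing methoxy of compound 3, or whether these changes would overlap.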